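Trading a Hydroxymethyl for a Methyl on a Shared Core

This account rests on a few compounds, and the source may have more. Where it says the series, first, only, none or still open, it means among the compounds named here.

Of the compounds shown here, three built on one shared core have been measured in a physicochemical assay for acid dissociation, using potentiometric titration. Compound 1, `O=c1ccn(CCN2CCCCC2)c(CO)c1O`, gives 7.35 in this assay. Compound 2, `Cn1cc(O)c(=O)cc1CN1CCCCC1`, gives 6.74, and compound 3, `CCc1c(O)c(=O)ccn1CCN(C)C`, gives 6.88. Compound 1 thus stands highest of the three: its nearest neighbour is compound 3, whose value lies lower by an amount beyond the scatter, and compound 2 lies lower still, also beyond the scatter.

The step followed here leads from compound 1 to compound 4, `Cc1c(O)c(=O)ccn1CCN1CCCCC1`, which has not yet been measured in this assay. The change is hydrogen in place of hydroxy on a saturated chain carbon bound to an aromatic carbon. Among the measured compounds shown here, no pair of measured compounds differs in exactly this way, so no measured step shows how large the effect of this change will be. Both compound 2 and compound 3 sit below compound 1, so a modest downward shift, near the edge of the scatter, seems the likeliest outcome, though a change within the scatter cannot be excluded. Compound 4 is therefore expected to give about 7, with a range from 6.6 to 7.4. The expected step is a number 0.35 log units lower from compound 1 to compound 4 (beyond the scatter).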

Compound 4, acid dissociation constant: 7.42
Estimate against measurement, compound 4: 0.42 log units below, and the stated range ends below it.
By their numbers in this assay, from the lowest: compounds 2 and 3 (each within the scatter of the next); then compounds 1 and 4 (each within the scatter of the next).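

In this assay, among the compounds shown here, the change from hydroxymethyl to methyl gives the first step that can be read at this position, a number 0.07 log units higher from compound 1 to compound 4 (within the scatter), and this step lies within the scatter, so the two compounds cannot be told apart by this read-out. The earlier compounds shown here could not show this, as no two of them differed in one place only; the pair now shows that, on this core, hydrogen can take the place of hydroxy on a saturated chain carbon bound to an aromatic carbon without a change that this assay can resolve. Nothing at hand bears on the reason for this outcome.

As far as these compounds go, whether that holds beyond this single pair remains open, as a single step says nothing about how an amine, a carboxylic acid or a longer chain at this carbon would read in this assay. Compound 2 and compound 3 differ from compound 4 in more than one place, so they do not show whether the same exchange would give a similar step with a different chain on the ring nitrogen.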